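This account rests on a few compounds, and the source may have more. Where it says the series, first, only, none or still open, it means among the compounds named here.

Compound 1 `COc1cc(OC)c2c(=O)cc(/C=C/c3ccc([N+](=O)[O-])cc3)oc2c1` gives 19700 nM in a functional assay on A549 cells (Homo sapiens) for antiproliferative activity, read by MTT assay, with a stated time of 12 h; on this read-out lower numbers stand for stronger inhibition and higher numbers for weaker inhibition.
Compound 2 `COc1cc(OC)c2c(=O)cc(/C=C/c3ccncc3)oc2c1` gives only a limit in this assay, > 40000 nM.
Compound 3 `COc1cc(OC)c2c(=O)cc(/C=C/c3ccc(OCC4CC4)cc3)oc2c1` gives 20900 nM in this assay.

Among the two numbers, compound 3 carries the higher one, with compound 1 nearest; the difference between them is within the scatter, so the two are not told apart. For the measured compounds named here, the one measured step on the shared core, a 1.1-fold higher number from compound 1 to compound 3 (0.03 log units; within the scatter), shows that exchanging one group on the aromatic carbon of the styryl ring for another leaves the number essentially where it was.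

Compound 4 `COc1cc(OC)c2c(=O)cc(/C=C/c3ccccc3)oc2c1` differs from compound 3 in one place: hydrogen in place of cyclopropylmethoxy on an aromatic carbon. Going by the values given here, no measured step removes a group at this position outright, so the expectation rests on compound 1 and compound 3, whose values sit together, and on compound 2, which in this assay reaches only the limit (the limit of > 40000 nM in this assay, at which 1 of the 3 values shown sits). The change from compound 3 to compound 4 is therefore expected to produce a step of about a 1.1-fold higher number from compound 3 to compound 4 (0.02 log units; within the scatter), within the scatter. Compound 4 is estimated at 22000 nM, between 8000 nM and 50000 nM.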

Compound 4, half-maximal inhibitory concentration: 21500 nM
Compound 4: the middle estimate sits 1.0-fold (0.01 log units) above what was measured; low and high end bracket the measured number.
By their numbers in this assay, from the lowest: compounds 1, 3 and 4 (each within the scatter of the next). At a limit, above all of these: compound 2.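

On this aromatic carbon, para to a large group, the substituent can be removed altogether without a readable change in this assay: the step is a 1.0-fold higher number from compound 3 to compound 4 (0.01 log units; within the scatter), and measured against the nitro compound it is a 1.1-fold higher number from compound 1 to compound 4 (0.04 log units; within the scatter). Plain hydrogen therefore joins nitro and cyclopropylmethoxy in one group of values, while replacing pyridin-4-yl with phenyl gives an at least 1.8-fold lower number from compound 2 to compound 4 (0.26 log units; that floor lies within the scatter), a floor that does not by itself separate that pair. Compound 2 remains at a limit, not a number: the limit of > 40000 nM in this assay, at which 1 of the 4 values shown sits.

Going by these compounds, whether an amine, a carboxylic acid or a longer chain on this carbon would move the number remains open. So does whether any group on another carbon of this ring would do so, and whether this flat picture would hold in other cells.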